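Thiophen-3-yl for pyridin-4-yl in a 2-chlorophenyl series

The source may hold more compounds than are shown below. What is called first, only, known or untested is meant among the compounds shown, and "the series" means these compounds.

Compound 2 `Oc1ccc(-c2cc(-c3ccncc3)nc(-c3ccccc3Cl)c2)cc1` has no single number in a functional assay on DU-145 cells (Homo sapiens) for cytotoxicity, read by CCK-8 assay and cell counting, with a stated time of 2 days; a lower number here means a stronger inhibitor, a higher number a weaker inhibitor; for compound 2 the entry there is "not determined" (no result reported), so it stands nowhere on the measured scale. Within the data shown here, the only number in the set belongs to compound 1 `Oc1ccc(-c2cc(-c3ccco3)nc(-c3ccccc3Cl)c2)cc1`, which in this assay gives 5300 nM. The change to compound 3 `Oc1ccc(-c2cc(-c3ccsc3)nc(-c3ccccc3Cl)c2)cc1` is thiophen-3-yl in place of pyridin-4-yl on an aromatic carbon. Among the measured compounds shown here, no measured step in this assay exists for such a change, so the size and direction cannot be set from the data; with compound 1 as the only anchor, a value near it is expected. Compound 3 is estimated at 5000 nM, within 1500 nM to 16000 nM.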

Compound 3, half-maximal inhibitory concentration: 3890 nM
Compound 3: the middle estimate sits 1.3-fold (0.11 log units) above what was measured, and the stated range covers the measured number.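

At the place next to the ring nitrogen, thiophen-3-yl and furan-2-yl can now be compared directly: thiophen-3-yl in place of furan-2-yl gives a 1.4-fold lower number from compound 1 to compound 3 (0.13 log units; within the scatter) in this assay, so this exchange does not separate the two compounds. Compound 2, with pyridin-4-yl, gives no number, so its step to compound 3 cannot be read.

Still open, as far as these compounds go, is whether an amine or a carboxylic acid at this place would give a step beyond the scatter. Nothing at hand bears on what lies behind the values of compound 1 and compound 3.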